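Swapping methyl for fluoro: one small change, twice over

A few compounds are considered here, and "the series" means these few. Any claim that something is new, unique, unknown or untested is made for them only; others in the source may bear on it.

Of the compounds shown here, three have so far been tested in a functional assay on the whole organism (strain NMRI) with Mus musculus as the target, with a stated time of 4 h; a lower number here means that less compound is needed, a higher number that more compound is needed for the effect. Compound 1 `Cc1ccc(-c2nc3ccc(Br)cn3c2/C=N/O)cc1` needs the least material: in this assay compound 1 gives 20 mg/kg. Compound 3 `Cc1ccc(Cn2cc(CO/N=C/c3c(-c4ccc(C)cc4)nc4ccc(Br)cn34)nn2)cc1` carries a much larger group on the oxime oxygen, and in this assay compound 3 gives 100 mg/kg. Compound 2 `Cc1ccc(Cn2cc(CO/N=C/c3c(-c4ccc(F)cc4)nc4ccc(Br)cn34)nn2)cc1` differs from compound 3 in one place, (fluoro in place of methyl on an aromatic carbon), and in this assay compound 2 gives 100 mg/kg. That single swap gave no change at the digits printed from compound 3 to compound 2 (within the scatter). The difference between the core of compound 1 and the core of compound 3 is not broken down here.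

Compound 4 `O/N=C/c1c(-c2ccc(F)cc2)nc2ccc(Br)cn12` has not yet been measured. It is related to compound 1 by the same change, (fluoro in place of methyl on an aromatic carbon), at a place described in exactly the same words as for the pair of compound 3 and compound 2. Among the measured compounds shown here, the only guide is therefore that earlier pair, where the swap left the dose unchanged within the scatter. The step is therefore expected to be no change at the digits printed from compound 1 to compound 4 (within the scatter), since the earlier swap gave no change at the digits printed from compound 3 to compound 2 (within the scatter). Compound 4 is accordingly estimated to need 20 mg/kg, most likely between 10 mg/kg and 40 mg/kg.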

Compound 4, minimum effective dose: 40 mg/kg
For compound 4 the middle estimate is 2.0-fold (0.30 log units) below the measured one; the measured number falls inside the stated range.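

On the core of compound 1, fluoro in place of methyl on an aromatic carbon gave a 2.0-fold higher number from compound 1 to compound 4 (0.30 log units; within the scatter) in this assay. Set beside the earlier swap, the result on one core does not differ meaningfully from the result on the other: the same change on two cores in this assay, no change at the digits printed (within the scatter) from compound 3 to compound 2 and a 2.0-fold higher number (0.30 log units; within the scatter) from compound 1 to compound 4, 2.0-fold (0.30 log units) apart, within the scatter of two such steps. So, in these two pairs, the swap behaves alike whether the oxime oxygen is free or carries the much larger group, but this does not show that methyl and fluoro are interchangeable on other cores or in other assays, and two pairs cannot establish a general rule for the series.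

On these data alone, only methyl and fluoro appear at this place on the ring, so it remains open how a chloro group, a methoxy group or an amine would affect the dose needed. The oxime oxygen is seen only free or with the much larger group, which leaves open what a short chain such as ethyl would do there.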